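The compounds below may be only part of what the source reports. "The series", "measured", "known", "first", "only" and "open" are said of these compounds alone.

Of the compounds shown here, three built on one shared core have been tested in a toxicity assay on NIH3T3 cells (Mus musculus) for cytotoxicity, read by resazurin assay; a higher number here means that more compound is needed for the effect, a lower number that less compound is needed. Compound 1, `CNC(=O)c1ccc(NCc2cncn2Cc2ccc(-c3ccccc3)cc2N)cc1-c1ccccc1`, gives > 1000 nM in this assay, a value that is a limit of the assay rather than a number. Compound 2, `COC(=O)c1ccc(NCc2cncn2Cc2ccccc2C)cc1-c1ccccc1`, gives 10000 nM in this assay. Compound 3, `CNC(=O)c1ccc(NCc2cncn2Cc2ccc(-c3ccccc3)cc2)cc1-c1ccccc1`, gives > 1000 nM in this assay, which again is a limit rather than a number. Among the measured compounds shown here, the one step measured between compounds that differ in a single place, a step that the two limits leave unreadable from compound 1 to compound 3, cannot be read in size, since (the limit of > 1000 nM in this assay, at which 2 of the 3 values shown sit). Compound 3 therefore stands at that limit, without a number of its own.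

Compound 4, `COc1ccc(NCc2cncn2Cc2ccc(-c3ccccc3)cc2)cc1-c1ccccc1`, differs from compound 3 in one place: methoxy in place of methylcarbamoyl on an aromatic carbon. No measured step changes this group, so none of the steps shown bears on this change, and nothing points to a direction. The estimated step that the limit leaves unreadable from compound 3 to compound 4 is expected to lie within the scatter. The expected value for compound 4 is 10000 nM, with a range from 1000 nM to 100000 nM, and a limit is the likely outcome.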

Compound 4, half-maximal effective concentration: > 1000 nM
Compound 4: a limit, no number (the forecaster's own chance of this, stated with the estimate: 60%); the middle value lies beyond the limit too.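

In this assay, among the compounds shown here, compound 4 gives > 1000 nM which is a limit and not a number, so no step from compound 3 to compound 4 can be read: the limit of > 1000 nM in this assay, at which 3 of the 4 values shown sit. Going by these compounds, whether methoxy in place of methylcarbamoyl changes the concentration needed for cytotoxicity at all stays open.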